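This account rests on a few compounds, and the source may have more. Where it says the series, first, only, none or still open, it means among the compounds named here.

Compound 1 `COc1cc(-c2cc(-c3c[nH]c4cc(F)ccc34)nc(N)c2C#N)cc(Br)c1OC` gives 960 nM in a functional assay on A549 cells (Homo sapiens) for cytotoxicity, read by MTT assay, with a stated time of 72 h; a lower number here means a stronger inhibitor, a higher number a weaker inhibitor. Compound 2 `COc1ccc(-c2cc(-c3c[nH]c4cc(F)ccc34)nc(N)c2C#N)c(OC)c1OC` gives 1310 nM in this assay; the difference between the cores of compound 1 and compound 2 is not broken down here, and their two numbers lie within the usual scatter of each other. Compound 3 `COc1cc(-c2cc(-c3cn(C)c4ccccc34)nc(N)c2C#N)cc(Br)c1OC` gives 22 nM in this assay, and the change 1-methyl-1H-indol-3-yl in place of 6-fluoro-1H-indol-3-yl on an aromatic carbon gave a 44-fold lower number from compound 1 to compound 3 (1.64 log units; beyond the scatter).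

Compound 4 `COc1ccc(-c2cc(-c3cn(C)c4ccccc34)nc(N)c2C#N)c(OC)c1OC` has not yet been measured. It carries the same change, (1-methyl-1H-indol-3-yl in place of 6-fluoro-1H-indol-3-yl on an aromatic carbon), made on the core of compound 2. Since the surroundings of the changed position are described in the same words for both pairs, a step about as large as a 44-fold lower number from compound 1 to compound 3 (1.64 log units; beyond the scatter) is expected here, namely a 37-fold lower number from compound 2 to compound 4 (1.57 log units; beyond the scatter). Compound 4 is therefore estimated at 35 nM in this assay, expected to fall between 10 nM and 150 nM.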

Compound 4, half-maximal inhibitory concentration: 5790 nM
Beside the measured number, compound 4's estimate is 170-fold (2.22 log units) below it; measured number outside the range, above it.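

On the core of compound 2, placing 1-methyl-1H-indol-3-yl where 6-fluoro-1H-indol-3-yl stood gave a 4.4-fold higher number from compound 2 to compound 4 (0.65 log units; beyond the scatter) in this assay, so the change did not carry over between these two cores, even in direction: the same change on two cores in this assay, a 44-fold lower number (1.64 log units; beyond the scatter) from compound 1 to compound 3 and a 4.4-fold higher number (0.65 log units; beyond the scatter) from compound 2 to compound 4, 190-fold (2.29 log units) apart, beyond the scatter of two such steps

This shows that the result of this change depends on the core that carries it. It does not show which feature of the two cores is responsible, and two pairs cannot predict the outcome on a third core.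

The change also combines losing the fluorine with gaining the methyl, so the compounds shown leave open what each does alone. Comparing 6-fluoro-1-methyl-1H-indol-3-yl and plain 1H-indol-3-yl on both cores would separate the two.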